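The source may hold more compounds than are shown below. What is called first, only, known or untested is meant among the compounds shown, and "the series" means these compounds.

Compound 1 `COc1cccc(C(=O)N(C)/N=C/c2ccc(OC)c(OC)c2)c1` gives 73% in a functional assay on the whole organism (lung, strain A/J) for inhibition, with Mus musculus as the target, with stated times of 1 h and 18 h, at a dose of 100 umol/kg by the oral route; on this read-out lower numbers stand for less inhibition and higher numbers for more inhibition at the one dose given (going by the name of the read-out).
Compound 2 `COc1ccc(/C=N/N(C)c2ncnc3ccccc23)cc1OC` gives 47%.
Compound 3 `COc1ccc(/C=N/N(C)C(=O)c2ccc(OC)c(OC)c2)cc1OC` gives 53%.

Among these three, compound 1 stands highest: compound 3 lies nearest to it and compound 2 furthest, and both gaps are beyond the scatter. For the measured compounds named here, only one pair of measured compounds differs in a single place, and it gives a number 20 percentage points lower from compound 1 to compound 3 (beyond the scatter), a methoxy entering in place of hydrogen on an aromatic carbon of the ring on the carbonyl carbon. Compound 2 has no single-place relation to compound 1; its value simply sits well below.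

Compound 4 `COc1ccc(/C=N/N(C)C(=O)c2ccc(O)cc2)cc1OC` has not yet been measured. Against compound 1 the change is 4-hydroxyphenyl in place of 3-methoxyphenyl on a carbonyl carbon. Going by the values given here, no measured step covers this exchange. Among the compounds with values here, the one step known concerns adding a methoxy to that ring and it lowered the number, whereas here the methoxy leaves and a hydroxyl arrives, so the known step bears only loosely. On this basis compound 4 is expected to sit somewhat below compound 1, with no confidence that the difference exceeds the scatter. The estimate for compound 4 is 63%, in a range from 38% to 85%. This estimate amounts to a number 10 percentage points lower from compound 1 to compound 4 (within the scatter), a small expected step downward, within the usual scatter.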

Compound 4, a percentage reported as inhibition, in the whole organism at one dose (the size of the read-out at that dose, not a potency): 65%
Beside the measured number, compound 4's estimate is 2 percentage points below it; the range from low to high includes it.
By their numbers in this assay, from the lowest: compounds 2 and 3 (each within the scatter of the next); then compounds 4 and 1 (each within the scatter of the next).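

In this assay, 4-hydroxyphenyl in place of 3-methoxyphenyl on a carbonyl carbon gives a number 8 percentage points lower from compound 1 to compound 4 (within the scatter) and so leaves the two compounds indistinguishable on this read-out. For the compounds shown here, the earlier step on this ring, a number 20 percentage points lower from compound 1 to compound 3 (beyond the scatter) when a methoxy entered, showed only that a change there can cost inhibition beyond the scatter. The new step shows that this position also accepts a different group, with the methoxy gone and a hydroxyl present, without a difference that can be told from the scatter, and nothing available explains this result.

From the compounds shown here alone, whether 3-hydroxyphenyl or 4-methoxyphenyl on the same carbonyl carbon would read like compound 1 or compound 4 remains open. Also open, going by these compounds, is what an amine or a carboxylic acid on that ring would give.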